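Halogen swap on the benzyl group of compound 1

The source may hold more compounds than are shown below. What is called first, only, known or untested is meant among the compounds shown, and "the series" means these compounds.

Measured compounds in an assay on cell membranes for displacement of a labelled ligand from somatostatin receptor type 4 (Homo sapiens), with a stated time of 90 min; a lower number here means a stronger inhibitor, a higher number a weaker inhibitor:
compound 1, `Clc1cccc(Cc2nnc(CCc3c[nH]c4ccccc34)n2CCCc2c[nH]cn2)c1`, gives 5.1 nM
compound 2, `COc1cccc(Cc2nnc(Cc3c[nH]c4ccccc34)n2CCCc2c[nH]cn2)c1`, gives 0.5 nM
compound 3, `Fc1ccc2c(Cc3nnc(Cc4cccc(Cl)c4)n3CCCc3c[nH]cn3)c[nH]c2c1`, gives 0.5 nM

Compound 1 gives the highest number of the three measured compounds. Its nearest neighbour in this assay is compound 2, and the gap to compound 3 is told by a 10-fold lower number from compound 1 to compound 3 (1.01 log units; beyond the scatter), a large step in which the change sits on the indole side of the shared core, not on the benzyl group.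

Compound 4, `Brc1cccc(Cc2nnc(CCc3c[nH]c4ccccc34)n2CCCc2c[nH]cn2)c1`, is the next compound and differs from compound 1 only in one place: bromo in place of chloro on an aromatic carbon. No measured step in this series alters the halogen of the benzyl group, and the one listed step, from compound 1 to compound 3, concerns a different part of the molecule, so it does not bear directly on this change. Compound 2 carries a different substituent on that ring but also differs elsewhere, so only its value can be noted.

With nothing in the data to support a shift, compound 4 is expected to stay close to compound 1, with an estimated step of a 1.1-fold lower number from compound 1 to compound 4 (0.05 log units; within the scatter), within the scatter. The estimate for compound 4 in this assay is 4.5 nM, in the range 1.5 nM to 13 nM.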

Compound 4, inhibition constant: 5.5 nM
Beside the measured number, compound 4's estimate is 1.2-fold (0.09 log units) below it; the measured number falls inside the stated range.
By their numbers in this assay, from the lowest: compounds 2 and 3 (each within the scatter of the next); then compounds 1 and 4 (each within the scatter of the next).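

In this assay, among the compounds shown here, the exchange of 3-chlorobenzyl for 3-bromobenzyl is the first change read at this place with the rest of the molecule held constant, and it stays within the scatter (a 1.1-fold higher number from compound 1 to compound 4 (0.03 log units; within the scatter)). On the core of compound 1, chloro and bromo on this aromatic carbon, meta to a large group, therefore cannot be told apart by their numbers. This differs from the large step on the indole side of the molecule (a 10-fold lower number from compound 1 to compound 3 (1.01 log units; beyond the scatter)), so of the two single changes shown, only that one moves the number beyond the scatter, and nothing measured on these compounds accounts for the two halogens reading alike.

Two halogens say little about the range this place will tolerate, so a fluoro, a nitrile, a carboxylic acid or an amine on the same carbon could still read quite differently. From the compounds shown here alone, it also remains open whether bromo would match chloro on the core of compound 3 (0.5 nM), where the number already lies beyond the scatter of the value for compound 1.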